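The source may hold more compounds than are shown below. What is called first, only, known or untested is meant among the compounds shown, and "the series" means these compounds.

Among the compounds with values here, in an assay on membranes from HeLa cells for displacement of a labelled ligand from adenosine receptor A3 (Homo sapiens), read by scintillation counting, with a stated time of 180 min, tested at 1 uM (on this read-out higher numbers stand for more inhibition at the one concentration tested (going by the name of the read-out) and lower numbers for less inhibition), compound 1 `CC1=C(C(=O)OC(C)(C)C)C(c2cccs2)NC(=O)N1` gives 7%, and only one other number has been measured alongside it. Compound 2 `CC1=C(C(=O)OC(C)(C)C)C(c2ccsc2)NC(=O)N1` gives 1% in this assay. Within the data shown here, that pair forms the single measured step, a number 6 percentage points lower from compound 1 to compound 2 (within the scatter), which sits on the saturated ring carbon and stays within the scatter. Compound 3 `CC1=C(C(=O)OC2CCC2)C(c2cccs2)NC(=O)N1` carries cyclobutyl in place of tert-butyl on an oxygen next to a carbonyl group. Among the measured compounds shown here, no measured step touches the oxygen of the ester, so nothing in the data points to a shift in this assay beyond the scatter for compound 3. Compound 3 is therefore expected to give 5%, between -10% and 20%, a step of a number 2 percentage points lower from compound 1 to compound 3 (within the scatter).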

Compound 3, a percentage reported as inhibition, at one concentration (the size of the read-out at that concentration, not a potency): 2%
Estimate against measurement, compound 3: 3 percentage points above, and the stated range covers the measured number.
By their numbers in this assay, from the lowest: compounds 2, 3 and 1 (each within the scatter of the next).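

The ester oxygen now has a measured step of its own: in this assay, cyclobutyl in place of tert-butyl gives a number 5 percentage points lower from compound 1 to compound 3 (within the scatter). Exchanging these two groups of equal heavy-atom count therefore does not move the number beyond the scatter, and the same holds for the earlier change on the saturated ring carbon. No evidence bears on this result. As far as these compounds go, whether an amine, a carboxylic acid or a longer chain on this oxygen would shift the number beyond the scatter remains open.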